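The compounds below may be only part of what the source reports. "The series", "measured", "known", "first", "only" and "open" are said of these compounds alone.

Measured compounds:
compound 1 `Cc1c(C(=O)N/N=C\c2ccccc2F)oc2cccc(O)c12` with >= 40000 nM;
compound 2 `Cc1c(C(=O)N/N=C\c2ccc(O)cc2)oc2cccc(O)c12` with 21700 nM;
compound 3 `Cc1c(C(=O)N/N=C\c2ccc(Br)cc2O)oc2cccc(O)c12` with 2050 nM.

The three share one core and differ only in the aryl group on a carbon with a double bond to nitrogen. In a functional assay on PC-3 cells (Homo sapiens) for inhibition (a lower number here means a stronger inhibitor, a higher number a weaker inhibitor), compound 1 gives >= 40000 nM, and this is a limit of the assay, not a number; compound 1 therefore stands at the weak end of what has been seen (the limit of >= 40000 nM in this assay, at which 1 of the 3 values shown sits). From compound 1 the two measured steps both lower the number: an at least 1.8-fold lower number from compound 1 to compound 2 (0.26 log units; that floor lies within the scatter) and an at least 19-fold lower number from compound 1 to compound 3 (1.29 log units; beyond the scatter). Between the two substituted aryl groups the step of an 11-fold lower number from compound 2 to compound 3 (1.02 log units; beyond the scatter) is the larger of the changes.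

Compound 4 `Cc1c(C(=O)N/N=C\c2ccc(F)cc2)oc2cccc(O)c12` is not yet measured. It differs from compound 1 in one place: 4-fluorophenyl in place of 2-fluorophenyl on a carbon with a double bond to nitrogen. Among the measured compounds shown here, the step that bears most closely on this is the one from compound 1 to compound 2, where a group carrying a substituent in the 4-position replaced the 2-fluorophenyl and gave a number that at least reached the measurable range. On that basis the expected step is an at least 1.6-fold lower number from compound 1 to compound 4 (0.20 log units; that floor lies within the scatter), a move that may or may not clear the scatter. Compound 4 is therefore estimated to give about 25000 nM in this assay, within a range from 8000 nM to 60000 nM, with a real chance that only a limit is reported.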

Compound 4, half-maximal inhibitory concentration: >= 40000 nM
Compound 4: only a limit was reported (the forecaster's own chance of this, stated with the estimate: 35%); at least 1.6-fold (0.20 log units) between middle value and limit.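

Moving the fluoro group, with 4-fluorophenyl in place of 2-fluorophenyl, does not lift the compound into the measurable range: in this assay compound 4 gives a limit of the assay and not a number, as compound 1 does, so the step between them cannot be read and neither placing of fluoro can be ranked: the limit of >= 40000 nM in this assay, at which 2 of the 4 values shown sit.

Set against the hydroxy analogue, fluoro in place of hydroxy gives an at least 1.8-fold higher number from compound 2 to compound 4 (0.26 log units; that floor lies within the scatter), and since that floor lies within the scatter, this pair alone does not establish that the hydroxy group matters. The clearer contrast is an at least 19-fold higher number from compound 3 to compound 4 (1.29 log units; beyond the scatter), which shows that a lone fluoro on the aryl group does not reproduce what the 4-bromo-2-hydroxyphenyl group gives, and among these four compounds that group alone reaches the low end of the values.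

Still open is which part of that group carries the difference, the bromo or the hydroxy, since a 4-bromophenyl or a 2-hydroxyphenyl group on the same carbon is not among the compounds shown. From the compounds shown here alone, how a 4-aminophenyl group would read in this assay also remains unknown.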